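Trading Bromo for Hydroxy in Compound 2

The source may report more compounds than this note shows. Statements on the series, on what has been measured and on what is new or still open speak of the compounds shown alone.

Of the compounds shown here, three built on one shared core have been measured in a physicochemical assay for lipophilicity, measured as octanol-water partition; a higher number here means a more lipophilic compound, a lower number a more polar compound. Compound 1 `O=C(COc1cccc2ccccc12)N/N=C/c1cccc(O)c1` gives 3.73. Compound 2 `O=C(COc1cccc2ccccc12)N/N=C/c1ccccc1Br` gives 4.81, and compound 3 `COc1cc(/C=N/NC(=O)COc2cccc3ccccc23)cc(OC)c1OC` gives 3.26. Compound 2 thus stands highest of the three: the step of a number 1.08 log units higher from compound 1 to compound 2 (beyond the scatter) separates it from its nearest neighbour, and compound 3 lies further away still. Compound 4 `O=C(COc1cccc2ccccc12)N/N=C/c1ccccc1O` has not yet been measured. It differs from compound 2 by hydroxy in place of bromo on an aromatic carbon. Going by the values given here, the one measured step that bears on this change is a number 1.08 log units higher from compound 1 to compound 2 (beyond the scatter), read in reverse, where the compound carrying bromo was the higher one; compound 1 carries 3-hydroxyphenyl rather than the 2-hydroxyphenyl of compound 4, so that step is a guide rather than an exact match. A downward step of roughly that size is therefore expected, a number 1.01 log units lower from compound 2 to compound 4 (beyond the scatter). In this assay compound 4 is estimated to give 3.8, with a likely range from 3.4 to 4.3.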

Compound 4, partition coefficient: 3.73
The estimate for compound 4 lay 0.07 log units above the measured number; measured number inside the range.
By their numbers in this assay, from the lowest: compound 3; then compounds 1 and 4 (each within the scatter of the next); then compound 2.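

In this assay, the exchange of bromo for hydroxy on an aromatic carbon ortho to a large group can now be read on its own, with the rest of the molecule unchanged: a number 1.08 log units lower from compound 2 to compound 4 (beyond the scatter). The other new comparison concerns only the place of the hydroxy group, and there the 2-hydroxyphenyl and 3-hydroxyphenyl forms do not separate: no change at the digits printed from compound 1 to compound 4 (within the scatter). The earlier step from compound 1 to compound 2 changed the group and its place together, whereas these two steps pull those changes apart and show the gap following the change of group in this set.

No measurement shown here explains these numbers. As far as these compounds go, it also remains open where compounds with an amine or a carboxylic acid at this same place would fall relative to compound 2 and compound 4.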